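A few compounds are considered here, and "the series" means these few. Any claim that something is new, unique, unknown or untested is made for them only; others in the source may bear on it.

Measured so far:
compound 1, `O=C1CC(c2c[nH]c3ccc(C(F)(F)F)cc23)C(=O)N1`, gives 9700 nM in an assay on isolated protein for inhibition of Indoleamine 2,3-dioxygenase 1 (Homo sapiens), with a stated time of 15 min; a lower number here means a stronger inhibitor, a higher number a weaker inhibitor;
compound 2, `O=C1CC(c2c[nH]c3cc(F)ccc23)C(=O)N1`, gives 3400 nM in this assay.

Compound 2 holds the lower of the two numbers. Its nearest neighbour is compound 1, whose number stands higher by a margin beyond the usual scatter, so compound 2 is the stronger inhibitor of the pair.

Compound 3, `O=C1CC(c2c[nH]c3cc(Cl)ccc23)C(=O)N1`, has not been measured. It differs from compound 2 in one place only: chloro in place of fluoro on an aromatic carbon. Among the measured compounds shown here, no measured pair differs in just this way, so the size of the step cannot be read from the data. A swap of one halogen for another in the same place is expected to move the number only modestly, toward a slightly stronger inhibitor, though possibly within the scatter. Compound 3 is therefore estimated at 2500 nM in this assay, with a likely range from 1000 nM to 6000 nM. Compound 3 is expected to show a step of a 1.4-fold lower number from compound 2 to compound 3 (0.13 log units; within the scatter).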

Compound 3, half-maximal inhibitory concentration: 2100 nM
For compound 3 the middle estimate is 1.2-fold (0.08 log units) above the measured one, within the range that was stated.
By their numbers in this assay, from the lowest: compounds 3 and 2 (each within the scatter of the next); then compound 1.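

Among the compounds shown here, the two compounds form the first pair that differs in one place only, so the effect of a single change on the shared core can now be read directly. On the aromatic carbon that is meta to a fused ring and para to a fused ring, chloro in place of fluoro gives a 1.6-fold lower number from compound 2 to compound 3 (0.21 log units; within the scatter) in this assay, so this assay does not tell these two halogens apart at this position. No measurement shown here explains why the two compounds read so alike.

From the compounds shown here alone, two halogens alone say little about how much this position tolerates, so its response to a larger or quite different group remains open. A bromo group, a methoxy group, an amine or a carboxylic acid in the same place could each test this, as could a plain hydrogen.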